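Compound 3 to compound 4: methylcarbamoyl to benzylcarbamoyl

The source may report more compounds than this note shows. Statements on the series, on what has been measured and on what is new or still open speak of the compounds shown alone.

Compound 1 `CNC(=O)CCCCn1c(=O)c(C)cn([C@@H]2O[C@H](CO[Si](C)(C)C(C)(C)C)[C@@]3(OS(=O)(=O)C=C3N)[C@H]2O[Si](C)(C)C(C)(C)C)c1=O`: 10000 nM
Compound 2 `COC(=O)n1c(=O)c(C)cn([C@@H]2O[C@H](CO[Si](C)(C)C(C)(C)C)[C@@]3(OS(=O)(=O)C=C3N)[C@H]2O[Si](C)(C)C(C)(C)C)c1=O`: > 100000 nM
Compound 3 `CNC(=O)CCCC(=O)n1c(=O)c(C)cn([C@@H]2O[C@H](CO[Si](C)(C)C(C)(C)C)[C@@]3(OS(=O)(=O)C=C3N)[C@H]2O[Si](C)(C)C(C)(C)C)c1=O`: 9100 nM

In an ADME assay on CCRF-CEM cells (Homo sapiens) for cytotoxicity, with a stated time of 4 days (on this read-out lower numbers stand for higher toxicity in this test and higher numbers for lower toxicity in this test), compound 3 gives 9100 nM, with a 1.1-fold lower number from compound 1 to compound 3 (0.04 log units; within the scatter). Compound 2 gives > 100000 nM, which is a limit of the assay.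

Compound 4 `Cc1cn([C@@H]2O[C@H](CO[Si](C)(C)C(C)(C)C)[C@@]3(OS(=O)(=O)C=C3N)[C@H]2O[Si](C)(C)C(C)(C)C)c(=O)n(C(=O)CCCC(=O)NCc2ccccc2)c1=O` has phenyl in place of hydrogen on a saturated chain carbon bound to an amide-type nitrogen. Going by the values given here, no measured step alters the methylcarbamoyl group itself. Changing the chain left the number within the scatter, as a 1.1-fold lower number from compound 1 to compound 3 (0.04 log units; within the scatter) shows. The large step, an at least 10-fold lower number from compound 2 to compound 3 (1.04 log units; beyond the scatter), puts the whole chain in place of methoxy, a far bigger replacement. The expected result is a 1.3-fold lower number from compound 3 to compound 4 (0.11 log units; within the scatter), with no step beyond the scatter anticipated. For compound 4 the estimated value is 7000 nM, with an expected range of 2000 nM to 25000 nM.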

Compound 4, half-maximal cytotoxic concentration: 8800 nM
Compound 4: middle estimate off by 1.3-fold (0.10 log units), on the low side, within the range that was stated.
By their numbers in this assay, from the lowest: compounds 4, 3 and 1 (each within the scatter of the next). At a limit, above all of these: compound 2.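

Methylcarbamoyl to benzylcarbamoyl is the first change shown to that group, and in this assay it gives a 1.0-fold lower number from compound 3 to compound 4 (0.01 log units; within the scatter). At this place, on a saturated chain carbon bound to an amide-type nitrogen, the read-out therefore tolerates one six-membered aromatic ring of carbon only without leaving the scatter. Nothing among the data shown accounts for this result.

From the compounds shown here alone, whether an amine or a carboxylic acid in place of benzyl would also stay within the scatter remains open. The same holds for a longer chain carrying the phenyl.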